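The source may report more compounds than this note shows. Statements on the series, on what has been measured and on what is new or still open speak of the compounds shown alone.

Measured in a functional assay on LOX IMVI cells (Homo sapiens) for inhibition, read by sulforhodamine B assay, with a stated time of 48 h; on this read-out higher numbers stand for weaker inhibition of growth and lower numbers for stronger inhibition of growth:

Compound 1, `COc1cc(-c2nn(-c3cccc(NC(=O)Nc4ccc(Cl)c(Cl)c4)c3)cc2-c2ccncc2)ccc1Cl`: 2620 nM.
Compound 2, `COc1cc(-c2nn(-c3cccc(NC(=O)c4ccc(Cl)c(C(F)(F)F)c4)c3)cc2-c2ccncc2)ccc1Cl`: a limit of the assay, > 32500 nM.
Compound 3, `COc1cc(-c2nn(-c3cccc(NC(=O)Nc4ccc(Cl)c(C(F)(F)F)c4)c3)cc2-c2ccncc2)ccc1Cl`: 4610 nM.

Compound 3 is one of the two compounds with a number rather than a limit; its nearest neighbour is compound 1, and the step of a 1.8-fold higher number from compound 1 to compound 3 (0.25 log units; within the scatter) lies within the scatter, so no order between them can be read. The third value, that of compound 2, is a limit (the limit of > 32500 nM in this assay, at which 1 of the 3 values shown sits).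

Compound 4, `COc1cc(-c2nn(-c3cccc(NC(=O)c4ccccc4)c3)cc2-c2ccncc2)ccc1Cl`, has not yet been measured in this assay. It differs from compound 3 by phenyl in place of (4-chloro-3-(trifluoromethyl)phenyl)amino on a carbonyl carbon. Going by the values given here, two measured steps bear on this change. The step of an at least 7.0-fold lower number from compound 2 to compound 3 (0.84 log units; beyond the scatter) shows that replacing a directly attached aryl on the carbonyl carbon by the corresponding arylamino gives an at least modest lower number, and the reverse direction is seen in an at least 12-fold higher number from compound 1 to compound 2 (1.09 log units; beyond the scatter), a large rise to the limit. Compound 4 makes the reverse change and in addition drops the chloro and trifluoromethyl, a part of the change without a measured counterpart here. The expected step is therefore an 8.7-fold higher number from compound 3 to compound 4 (0.94 log units; beyond the scatter), large and towards a higher number, most likely ending at a limit. The estimate for compound 4 is 40000 nM, with a range from 12000 nM to 120000 nM.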

Compound 4, concentration for total growth inhibition: > 100000 nM
Compound 4: a limit, no number; the forecaster's own chance of this, stated with the estimate: 65%; middle value at least 2.5-fold (0.39 log units) from the limit.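

In this assay, compound 4 gives a limit of the assay and not a number: the limit of > 100000 nM in this assay, at which 1 of the 4 values shown sits.

Replacing the (4-chloro-3-(trifluoromethyl)phenyl)amino group on the carbonyl carbon with plain phenyl gives an at least 21-fold higher number from compound 3 to compound 4 (1.33 log units; beyond the scatter), and the comparison with the dichloro urea gives an at least 38-fold higher number from compound 1 to compound 4 (1.58 log units; beyond the scatter), so a large step also appears when the aryl group on the carbonyl carbon carries neither chloro nor trifluoromethyl. Compounds 2 and 4, with an aryl group directly on the carbonyl carbon, now both stand at limits, while compounds 1 and 3, with an arylamino group there, give numbers; no compound shown goes against this, but the step between compound 2 and compound 4 cannot be read, since both values are limits.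

The compounds shown leave open how an unsubstituted phenylamino group on the carbonyl carbon would read, which would separate the contribution of the ring's chloro and trifluoromethyl groups from that of the nitrogen. They also leave open whether the nitrogen with its hydrogen is needed, which a carbamate oxygen or a methylene group in its place would test.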